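The source may report more compounds than this note shows. Statements on the series, on what has been measured and on what is new or still open speak of the compounds shown alone.

Compound 1 `CN(C)c1cccc(C(=O)/C=C/c2ccncc2)c1`: 19000 nM.
Compound 2 `C(=C/c1noc2ccccc12)\c1ccncc1`: > 100000 nM.
Compound 3 `COc1cc(C(=O)/C=C/c2cccnc2)cc(OC)c1OC`: 30000 nM.

In a functional assay with Rattus norvegicus as the target (a lower number here means a stronger inhibitor, a higher number a weaker inhibitor), compound 3 gives 30000 nM, the higher of the two numbers shown, while compound 1 gives 19000 nM, which sits within the scatter of that reading. For compound 2 the entry > 100000 nM is a limit of this assay and not a number. Compound 4 `COc1cc(C(=O)/C=C/c2cc[n+](C)cc2)cc(OC)c1OC` differs from compound 3 by a group of 7 heavy atoms (6 carbon, 1 nitrogen; one six-membered aromatic ring with 1 hetero atom) in place of a group of 6 heavy atoms (5 carbon, 1 nitrogen; one six-membered aromatic ring with 1 hetero atom), on a double-bonded chain carbon bound to a double-bonded chain carbon. Among the measured compounds shown here, no measured pair shows a change of this kind, so its size has no anchor among the numbers given. A step toward a weaker inhibitor in this assay is expected, of moderate size, with a real chance that only a limit is returned. The expected step is a 2.0-fold higher number from compound 3 to compound 4 (0.30 log units; within the scatter). Compound 4 is estimated at 60000 nM, between 20000 nM and 200000 nM.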

Compound 4, half-maximal inhibitory concentration: > 50000 nM
Compound 4 gave a limit, no number; the forecaster's own chance of this, stated with the estimate: 35%; the middle value is on the limit's open side.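

In this assay compound 4 carries a limit of the assay and not a number, > 50000 nM: the limit of > 50000 nM in this assay, at which 1 of the 4 values shown sits. Replacing the uncharged pyridin-3-yl on this double-bonded chain carbon with a group of net charge +1 gives an at least 1.6-fold higher number from compound 3 to compound 4 (0.22 log units; that floor lies within the scatter). This is the first change shown at this place, and it yields no stronger inhibitor, though the true size of the step cannot be read from a limit. As far as these compounds go, whether a phenyl group or a carboxylic acid at this place would match compound 3 stays open.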